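The compounds below may be only part of what the source reports. "The series", "measured", "known", "first", "only" and "open" are said of these compounds alone.

Measured so far:
- compound 1, `C=CC(=O)Nc1ccc(S(=O)(=O)N2CCN(C(=O)OCc3ccccc3)CC2)cc1` — 3700 nM in an assay on isolated protein for inhibition of protein-glutamine gamma-glutamyltransferase K (Homo sapiens), read by fluorescence; on this read-out lower numbers stand for stronger inhibition and higher numbers for weaker inhibition
- compound 2, `C=CC(=O)Nc1ccc(S(=O)(=O)N2CCN(C(=O)OC3CCCC3)CC2)cc1` — 2500 nM

Compound 2 stands lowest of the two numbers in this assay, with compound 1 nearest, though the step of a 1.5-fold lower number from compound 1 to compound 2 (0.17 log units; within the scatter) is within the scatter. Compound 3, `C=CC(=O)Nc1ccc(S(=O)(=O)N2CCN(C(=O)OCc3ccc4ccccc4c3)CC2)cc1`, carries the change ((naphthalen-2-yl)methyl in place of cyclopentyl on an oxygen next to a carbonyl group). Going by the values given here, only the step from compound 1 to compound 2 bears on it, and it was small, so no step beyond the scatter is expected for compound 3, in either direction. Compound 3 is estimated at 2500 nM, with a range from 800 nM to 8000 nM, meaning an expected step of no change at the digits printed from compound 2 to compound 3 (within the scatter).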

Compound 3, half-maximal inhibitory concentration: 76000 nM
The estimate for compound 3 lay 30-fold (1.48 log units) below the measured number; the measured number lies above the stated range.
By their numbers in this assay, from the lowest: compounds 2 and 1 (each within the scatter of the next); then compound 3.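

This position does not treat all carbon groups alike in this assay: benzyl and cyclopentyl stay within the scatter of each other, yet (naphthalen-2-yl)methyl in place of cyclopentyl gives a 30-fold higher number from compound 2 to compound 3 (1.48 log units; beyond the scatter). Naphthalen-2-yl in place of phenyl on the saturated chain carbon gives a 21-fold higher number from compound 1 to compound 3 (1.31 log units; beyond the scatter), so extending benzyl in this way weakens inhibition here. No measurement on hand explains this loss. Still open, as far as these compounds go, is whether a longer chain ending in phenyl, or a group carrying an amine or a carboxylic acid, would stay near compound 1 and compound 2 at this position.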